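Swapping Halogens on the Saturated-Ring Phenyl Group

A few compounds are considered here, and "the series" means these few. Any claim that something is new, unique, unknown or untested is made for them only; others in the source may bear on it.

Of the compounds shown here, three have so far been tested in a functional assay on PC-3 cells (Homo sapiens) for antiproliferative activity, read by MTT assay, tested at 5 uM; a higher number here means a stronger effect of the compound at the concentration tested, a lower number a weaker effect. Compound 1 `COc1cc(C(=O)N/N=C/c2ccccc2C(F)(F)F)cc(OC)c1OC` gives 52.9%, and compound 2 `COc1cc(C(=O)N/N=C/c2ccccc2F)cc(OC)c1OC` gives 81.8%. Among the measured compounds shown here, the only one-place step between measured compounds is a number 28.9 percentage points higher from compound 1 to compound 2 (beyond the scatter), a change of fluoro in place of trifluoromethyl on an aromatic carbon. Compound 3 `COc1cc(C2=NN(C(C)=O)C(c3ccc(F)c(F)c3)O2)cc(OC)c1OC` gives 46.9%, the lowest of the three numbers, although compound 1 stands nearest to it and within the scatter, while compound 2 stands furthest away and beyond the scatter.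

Compound 4 `COc1cc(C2=NN(C(C)=O)C(c3cc(Cl)cc(Cl)c3)O2)cc(OC)c1OC` differs from compound 3 in a single place: 3,5-dichlorophenyl in place of 3,4-difluorophenyl on a saturated ring carbon. For the measured compounds named here, none of the measured steps bears directly on this change. Going by the values given here, the one known step, between compound 1 and compound 2, concerns a group on an aromatic carbon in a different part of the molecule, and neither of those compounds carries the five-membered ring shared by compound 3 and compound 4. With no guide from the data, the step from compound 3 to compound 4 is expected to be of no size beyond the scatter, a number 0.9 percentage points lower from compound 3 to compound 4 (within the scatter). Compound 4 is therefore estimated to give 46% in this assay, within a range from 26% to 66%.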

Compound 4, a percentage reported as inhibition, at one concentration (the size of the read-out at that concentration, not a potency): 93.9%
Compound 4: middle estimate off by 47.9 percentage points, on the low side; the measured number lies above the stated range.
By their numbers in this assay, from the lowest: compounds 3 and 1 (each within the scatter of the next); then compound 2; then compound 4.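

In this assay, the phenyl group on the saturated ring carbon proves to be a sensitive position in this series, with a number 47 percentage points higher from compound 3 to compound 4 (beyond the scatter) when 3,5-dichlorophenyl replaces 3,4-difluorophenyl. The size of this step stands out. The swap leaves the counted features unchanged: both groups have the same number of heavy atoms, a single six-membered aromatic ring of carbon, no hydrogen-bond donors or acceptors and no net charge. Nothing available explains why the two groups differ so strongly at this position.

This one swap changes both the halogen, from fluorine to chlorine, and where the two halogens sit on the phenyl ring, and the compounds shown cannot tell these two changes apart. Going by these compounds, it also remains open how the same position would respond to a plain phenyl group, or to a phenyl group carrying a methoxy group or an amine, and whether the high number of compound 4 depends on chlorine itself.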